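Swapping a Phenyl Amide Partner for a Thiazole

The compounds below may be only part of what the source reports. "The series", "measured", "known", "first", "only" and "open" are said of these compounds alone.

Of the compounds shown here, three have been measured in a physicochemical assay for lipophilicity, read by HPLC, at pH 7.4; a higher number here means a more lipophilic compound, a lower number a more polar compound. Compound 1 `NCc1csc(NC(=O)c2ccon2)n1` gives -0.1 in this assay, and compound 2 `NCc1csc(NC(=O)c2ncccn2)n1` gives -0.1. Compound 3 `CC(C)(C)c1cc(C(=O)Nc2cccc(CN)c2)n(Cc2ccccc2)n1` stands highest of the three with 2.9, a value well beyond the scatter above both compound 1 and compound 2, each of which sits the same distance below it.

The unmeasured compound 4 `CC(C)(C)c1cc(C(=O)Nc2nc(CO)cs2)n(Cc2ccccc2)n1` keeps the core of compound 3 and changes only the group on the amide-type nitrogen: 4-(hydroxymethyl)-1,3-thiazol-2-yl in place of 3-(aminomethyl)phenyl on an amide-type nitrogen. The leaving group carries an aminomethyl substituent on a carbon-only six-membered ring, the entering group a hydroxymethyl substituent on a five-membered ring with two hetero atoms.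

For the measured compounds named here, no measured pair shows exactly this exchange, so the expectation rests on compound 3 alone. Compound 4 is expected to run higher than compound 3, with an estimated step of a number 0.80 log units higher from compound 3 to compound 4 (beyond the scatter) in this assay, beyond the scatter. The estimated value for compound 4 is 3.7, within a range from 3.1 to 4.3.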

Compound 4, distribution coefficient: 3.4
Compound 4: the middle estimate sits 0.30 log units above what was measured; the range from low to high includes it.
By their numbers in this assay, from the lowest: compounds 1 and 2 (each within the scatter of the next); then compound 3; then compound 4.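

For the compounds shown here, on the amide-type nitrogen of the core of compound 3, 4-(hydroxymethyl)-1,3-thiazol-2-yl in place of 3-(aminomethyl)phenyl reads in this assay as a number 0.50 log units higher from compound 3 to compound 4 (beyond the scatter), the first step in the set across a single place. This exchange changes the substituent from aminomethyl to hydroxymethyl and the ring from a carbon-only six-membered ring to a five-membered ring with two hetero atoms, so the step belongs to the whole group and cannot be divided between these two parts. No measurement at hand accounts for the step.

The compounds shown leave open what the ring and the substituent each contribute, which a 3-(hydroxymethyl)phenyl or a 4-(aminomethyl)-1,3-thiazol-2-yl group at this place could separate. Also open, as far as these compounds go, is how a carboxylic acid or a longer chain in place of the hydroxymethyl would read.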